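Trading a methylphenyl for an indole on the thiazolidinone

The source may report more compounds than this note shows. Statements on the series, on what has been measured and on what is new or still open speak of the compounds shown alone.

Measured compounds:
compound 1, `O=C(CN1C(=O)c2ccccc2C1=O)NN1C(=O)CSC1c1ccc(O)cc1`, a physicochemical assay for lipophilicity, in phosphate buffer, measured as octanol-water partition, with a stated time of 24 h; a higher number here means a more lipophilic compound, a lower number a more polar compound: 2.4
compound 2, `Cc1ccc(C2SCC(=O)N2NC(=O)CN2C(=O)c3ccccc3C2=O)cc1`: 2.97
compound 3, `CN(C)c1ccc(C2SCC(=O)N2NC(=O)CN2C(=O)c3ccccc3C2=O)cc1`: 2.84

Among the three measured compounds, compound 2 stands highest in this assay; its nearest neighbour is compound 3, which lies a number 0.13 log units lower from compound 2 to compound 3 (within the scatter), within the scatter, while compound 1 lies furthest, as a number 0.57 log units higher from compound 1 to compound 2 (beyond the scatter) shows. The two steps from compound 1 each concern a single group on an aromatic carbon: a number 0.57 log units higher from compound 1 to compound 2 (beyond the scatter) and a number 0.44 log units higher from compound 1 to compound 3 (beyond the scatter), both modest and both beyond the scatter.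

Compound 4, `O=C(CN1C(=O)c2ccccc2C1=O)NN1C(=O)CSC1c1c[nH]c2ccccc12`, has not yet been measured. Its change from compound 2 is of a different kind: 1H-indol-3-yl in place of 4-methylphenyl on a saturated ring carbon. Here the whole 4-methylphenyl group leaves and 1H-indol-3-yl enters, bringing one hydrogen-bond donor where compound 2 had none. Among the measured compounds shown here, no measured step covers such a swap of the entire aromatic group, so the steps from compound 1 give only loose guidance. On that basis a modest step downward in this assay is expected for compound 4, estimated as a number 0.47 log units lower from compound 2 to compound 4 (beyond the scatter). The estimate for compound 4 in this assay is 2.5, with an expected range from 2.1 to 2.9.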

Compound 4, partition coefficient: 1.59
Beside the measured number, compound 4's estimate is 0.91 log units above it, outside the stated range (below it).
By their numbers in this assay, from the lowest: compound 4; then compound 1; then compounds 3 and 2 (each within the scatter of the next).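

In this assay, among the compounds shown here, the earlier compounds showed only single groups changing on the aromatic ring, and none of those steps exceeded modest size. Replacing the whole aromatic group on the saturated ring carbon moves the number much further, with a number 1.38 log units lower from compound 2 to compound 4 (beyond the scatter) and a number 1.25 log units lower from compound 3 to compound 4 (beyond the scatter) both large, so this position tolerates far more change in the read-out than the earlier substituent swaps suggested. Even the compound lowest among the earlier three is passed, with a number 0.81 log units lower from compound 1 to compound 4 (beyond the scatter) as a modest step, which places 1H-indol-3-yl below 4-methylphenyl, 4-(dimethylamino)phenyl and 4-hydroxyphenyl at this position, although no measurement at hand accounts for the size of these steps.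

The swap to 1H-indol-3-yl brings in a second aromatic ring, a ring nitrogen and its hydrogen all at once, so these compounds cannot say which of these features goes with the lower number. As far as these compounds go, a 1-methylindol-3-yl group, a naphthyl group or a plain phenyl group at the same saturated ring carbon would pull these features apart, and how a pyridyl group would compare also remains open.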